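The compounds below may be only part of what the source reports. "The series", "measured", "known", "first", "only" and "open" are said of these compounds alone.

Measured compounds:
compound 1 `Cc1ccc(Cn2c(/C=C3\SC(=S)N(CC(=O)O)C3=O)nc3cc(F)ccc32)cc1`: 2380 nM
compound 2 `COc1ccc2c(c1)nc(/C=C1\SC(=S)N(CC(=O)O)C1=O)n2Cc1ccc(C)cc1`: 1820 nM
compound 3 `O=C(O)CN1C(=O)/C(=C/c2nc3ccc(F)cc3n2Cc2ccccc2F)SC1=S`: > 50000 nM, a limit of the assay, not a number

In a functional assay on HeLa cells (Homo sapiens) for cytotoxicity, read by MTT assay, with a stated time of 48 h (a lower number here means a stronger inhibitor, a higher number a weaker inhibitor), compound 1 gives 2380 nM and compound 2 gives 1820 nM, a step of a 1.3-fold lower number from compound 1 to compound 2 (0.12 log units; within the scatter) made by methoxy in place of fluoro on an aromatic carbon. Compound 3 sits at the limit of > 50000 nM in this assay, at which 1 of the 3 values shown sits, and no number is known for it. How the core of compound 3 differs from that of compound 1 is not broken down here.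

Compound 4 `COc1ccc2nc(/C=C3\SC(=S)N(CC(=O)O)C3=O)n(Cc3ccccc3F)c2c1` is not yet measured. It differs from compound 3 by methoxy in place of fluoro on an aromatic carbon, the same change as made from compound 1 to compound 2, at the same place. Since that earlier step was within the scatter and compound 3 sits at the limit, the step from compound 3 to compound 4 is expected to be a number no higher from compound 3 to compound 4 (the limit leaves the size open), most likely leaving compound 4 at the limit as well. Compound 4 is thus estimated at 50000 nM, between 15000 nM and 100000 nM.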

Compound 4, half-maximal inhibitory concentration: 28100 nM
For compound 4 the middle estimate is 1.8-fold (0.25 log units) above the measured one, within the range that was stated.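

In this assay, methoxy in place of fluoro on an aromatic carbon gives an at least 1.7-fold lower number from compound 3 to compound 4 (0.25 log units; that floor lies within the scatter), and on neither core does the change raise the number. Set beside the earlier step, this does not show that the change has the same size on both cores, nor that its size differs: the same change on two cores in this assay, a 1.3-fold lower number (0.12 log units; within the scatter) from compound 1 to compound 2 and an at least 1.7-fold lower number (0.25 log units; that floor lies within the scatter) from compound 3 to compound 4; the limit leaves it open whether they differ Compound 3 stands at a limit of the assay and not at a number, which leaves the true size of this step unknown: the limit of > 50000 nM in this assay, at which 1 of the 4 values shown sits.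

The compounds shown leave open how an amine or a longer chain such as ethoxy would read on that aromatic carbon. On these data alone, whether methoxy would behave alike on any core beyond these two also stays open.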